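Bulkier esters on a shared dihydropyridine-type core

This account rests on a few compounds, and the source may have more. Where it says the series, first, only, none or still open, it means among the compounds named here.

Measured so far:
- compound 1, `COC(=O)C1=C(C)NC(C)=C(C(=O)OC)C1c1csc(-c2ccc(Cl)cc2)n1`: 4430 nM
- compound 2, `CC1=C(C(=O)OCCc2ccccc2)C(c2csc(-c3ccc(Cl)cc3)n2)C(C(=O)OCCc2ccccc2)=C(C)N1`: 500000 nM
- compound 3, `CCOC(=O)C1=C(C)NC(C)=C(C(=O)OC(C)(C)C)C1c1csc(-c2ccc(Cl)cc2)n1`: 91000 nM

Three compounds share one core and differ only in the two ester groups. In an assay on isolated protein for antagonist activity at Voltage-dependent L-type calcium channel subunit alpha-1C (Cavia porcellus), with a stated time of 15 min (a higher number here means a weaker inhibitor, a lower number a stronger inhibitor), compound 1 gives 4430 nM, the lowest of the three numbers. Compound 3 comes nearest with 91000 nM, a gap beyond the scatter, and compound 2 lies furthest with 500000 nM, also beyond the scatter. Among these three, the two compounds with larger ester groups both give higher numbers than compound 1.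

Compound 4, `COC(=O)C1=C(C)NC(C)=C(C(=O)OC(C)c2ccccc2)C1c1csc(-c2ccc(Cl)cc2)n1`, is not yet measured. It differs from compound 1 in one place: 1-phenylethyl in place of methyl on an oxygen next to a carbonyl group. Since compound 2 and compound 3 both show higher numbers than compound 1 after their esters were enlarged, compound 4 is expected to move in the same direction in this assay, by a step of moderate size, beyond the scatter but smaller than that seen for compound 2. The estimate for compound 4 is 20000 nM, within 5000 nM to 100000 nM, which as a step means a 4.5-fold higher number from compound 1 to compound 4 (0.65 log units; beyond the scatter).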

Compound 4, half-maximal inhibitory concentration: 7620 nM
Compound 4: middle estimate off by 2.6-fold (0.42 log units), on the high side; the measured number falls inside the stated range.
By their numbers in this assay, from the lowest: compounds 1 and 4 (each within the scatter of the next); then compound 3; then compound 2.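

Among the compounds shown here, compound 4 is the only compound here that changes a single ester while the other keeps its methyl, so it gives the first one-place reading at this position. In this assay, 1-phenylethyl in place of methyl on an oxygen next to a carbonyl group gives a 1.7-fold higher number from compound 1 to compound 4 (0.24 log units; within the scatter), so this step, which brings in a six-membered aromatic ring and 8 heavy atoms, separates compound 4 from compound 1 by no more than repeated measurements would. No measured evidence bears on why this is so.

The compounds shown leave open whether the other ester position would respond in the same way to 1-phenylethyl. They also leave open how this position would respond to an ester chain ending in an amine, or to a carboxylic acid in place of the methyl ester.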